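Chloroacetamide in Place of the Acylurea Arm

The compounds below may be only part of what the source reports. "The series", "measured", "known", "first", "only" and "open" are said of these compounds alone.

Compound 3 `CCCCC(OC)c1cccc(NC(=O)NC(=O)CC)c1` carries a propanoyl group on the urea nitrogen of the shared core. In a functional assay on HT-29 cells (Homo sapiens) for antiproliferative activity, with a stated time of 48 h (a higher number here means a weaker inhibitor, a lower number a stronger inhibitor), compound 3 gives only a limit of the assay, > 100000 nM, and no number. Its two measured neighbours differ from it in one place each. Compound 1 `CCCCC(OC)c1cccc(NC(=O)NCCCCl)c1` gives 56000 nM in this assay, and compound 2 `CCCCC(OC)c1cccc(NC(=O)NC(=O)CCl)c1` gives 10000 nM. Exchanging the 3-chloropropyl for a (chloromethyl)carbonyl lowered the number a 5.6-fold lower number from compound 1 to compound 2 (0.75 log units; beyond the scatter), whereas the propanoyl left compound 3 at its limit an at least 1.7-fold higher number from compound 1 to compound 3 (0.25 log units; that floor lies within the scatter). Most telling is the chloro-to-methyl exchange on the chain carbon bound to the carbonyl, which raised the number an at least 10-fold higher number from compound 2 to compound 3 (1.00 log units; beyond the scatter).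

Compound 4 `CCCCC(OC)c1cccc(NC(=O)CCl)c1` has not been measured; it differs from compound 3 by chloromethyl in place of propanoylamino on a carbonyl carbon. Compound 4 thus keeps the chloromethyl carbonyl of compound 2 while shedding the second carbonyl and nitrogen. That chloro-bearing carbonyl is what separated compound 2 from compound 3, so a move down from the limit is expected. The step from compound 3 to compound 4 is estimated at an at least 6.6-fold lower number from compound 3 to compound 4 (0.82 log units; beyond the scatter). Compound 4 is expected to give 15000 nM in this assay, within a range from 3000 nM to 100000 nM.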

Compound 4, half-maximal inhibitory concentration: 13000 nM
Compound 4: middle estimate off by 1.2-fold (0.06 log units), on the high side; measured number inside the range.
By their numbers in this assay, from the lowest: compounds 2 and 4 (each within the scatter of the next); then compound 1. At a limit, above all of these: compound 3.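

Compound 3 remains a limit of the assay and not a number: the limit of > 100000 nM in this assay, at which 1 of the 4 values shown sits. Even so, this assay gives a readable floor for the exchange on the carbonyl carbon, with chloromethyl in place of propanoylamino producing an at least 7.6-fold lower number from compound 3 to compound 4 (0.88 log units; beyond the scatter), and with chloromethyl in place of (3-chloropropyl)amino the result is a 4.3-fold lower number from compound 1 to compound 4 (0.63 log units; beyond the scatter). New here is that the urea part of compound 2 proves dispensable in this assay, since replacing ((chloromethyl)carbonyl)amino with chloromethyl gives a 1.3-fold higher number from compound 2 to compound 4 (0.11 log units; within the scatter), so that a single carbonyl bearing chloromethyl on the amide-type nitrogen does as well as the longer arm, and both compounds that carry this chloromethyl carbonyl stand apart from compound 1, whose chlorine sits on a propyl chain.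

The compounds shown leave open whether the chlorine itself is required on that carbon, as a bromomethyl, a fluoromethyl or a plain methyl on the carbonyl carbon of compound 4 would show. They also leave open how far the number depends on the rest of the shared core, for which a longer chain or an amine in place of the methoxy group would be a test.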